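This account rests on a few compounds, and the source may have more. Where it says the series, first, only, none or still open, it means among the compounds named here.

Measured so far in an in vitro ADME assay on microsomes from liver (Rattus norvegicus) for metabolic stability (on this read-out lower numbers stand for slow clearance and higher numbers for fast clearance), are three compounds:
Compound 1 `CN1C(=O)C(C)(C)C[C@H]1C(=O)NCc1cccc(C(F)(F)F)c1Cl` gives < 0.5 mL.min-1.g-1 as a limit of the assay
Compound 2 `CN1CCC(N2C[C@@H](C(=O)NCc3cccc(C(F)(F)F)c3Cl)N(C)C2=O)CC1` gives 0.5 mL.min-1.g-1 as a number
Compound 3 `Cc1cc(N2C[C@@H](C(=O)NCc3cccc(C(F)(F)F)c3Cl)N(C)C2=O)ccn1` gives 3.7 mL.min-1.g-1 as a number

Among the compounds with values here, compound 2 holds the lower of the two actual numbers in this assay at 0.5 mL.min-1.g-1 and the only other number is that of compound 3 at 3.7 mL.min-1.g-1 in the same read-out. The value of compound 1 is a limit and not a number.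

Compound 4 `CN1C(=O)N(c2nccn2C)C[C@H]1C(=O)NCc1cccc(C(F)(F)F)c1Cl` has not yet been measured. It carries 1-methyl-1H-imidazol-2-yl in place of 1-methylpiperidin-4-yl on an amide-type nitrogen in a ring and differs from compound 2 in that one group.

Within the data shown here, the one measured step that bears on this shows a 7.4-fold higher number from compound 2 to compound 3 (0.87 log units; beyond the scatter) with 2-methylpyridin-4-yl entering at the same place. That modest step lies beyond the scatter. Among the measured compounds shown here, in both changes an aromatic ring replaces 1-methylpiperidin-4-yl, but the entering ring differs, and no compound with 1-methyl-1H-imidazol-2-yl has a value yet. A rise in the same direction is therefore expected, of somewhat smaller size and resting on a single precedent.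

The expected step is a 4.0-fold higher number from compound 2 to compound 4 (0.60 log units; beyond the scatter) in this assay by this estimate. Compound 4 is expected at 2 mL.min-1.g-1 in a range from 0.7 mL.min-1.g-1 to 5.5 mL.min-1.g-1 on that reckoning.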

Compound 4, intrinsic clearance in microsomes: 0.9 mL.min-1.g-1
Compound 4: middle estimate off by 2.2-fold (0.35 log units), on the high side; measured number inside the range.
By their numbers in this assay, from the lowest: compounds 2 and 4 (each within the scatter of the next); then compound 3.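

Compound 3 alone left open whether any aromatic ring in place of 1-methylpiperidin-4-yl on this amide-type nitrogen would lift the clearance number, but 1-methyl-1H-imidazol-2-yl does not separate from the piperidine in this assay: the result is a 1.8-fold higher number from compound 2 to compound 4 (0.26 log units; within the scatter). Which aromatic ring enters therefore matters, as the comparison on the same core gives a 4.1-fold lower number from compound 3 to compound 4 (0.61 log units; beyond the scatter). Among these three compounds, a low number at this place is thus shared by the non-aromatic 1-methylpiperidin-4-yl of compound 2 and the five-membered aromatic ring of compound 4, while compound 3 with 2-methylpyridin-4-yl goes against any rule that aromatic rings here give a higher number.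

From the compounds shown here alone, it stays open whether the methyl groups on these rings play any part, and whether a plain phenyl, an unsubstituted pyridine or a ring carrying an amine or a carboxylic acid at this place would fall with compound 4 or with compound 3. The value of compound 1 is a limit, and how far any group at this place could go lower in this assay stays open with it: the limit of < 0.5 mL.min-1.g-1 in this assay, at which 1 of the 4 values shown sits.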